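A Triazole-Free Tour of Three Limits and a Fourth Guess

The compounds below may be only part of what the source reports. "The series", "measured", "known", "first", "only" and "open" are said of these compounds alone.

Going by the values given here, the three compounds measured so far share one core and differ only in the substituted phenyl ring on an aromatic nitrogen. Compound 1 `C/C(=C\CC/C(C)=C/CC[C@@H]1[C@@]2(C)CCC(=O)C(C)(C)[C@H]2CC[C@@]1(C)O)CC/C=C(\C)C(=O)OCc1cn(-c2ccccc2C(F)(F)F)nn1` carries a 2-(trifluoromethyl)phenyl group, and in an ADME assay on L132 cells (Homo sapiens) for cytotoxicity, read by MTT assay, with a stated time of 48 h (on this read-out higher numbers stand for weaker inhibition and lower numbers for stronger inhibition), compound 1 gives > 150000 nM, which is a limit of the assay rather than a number. Compound 2 `C/C(=C\CC/C(C)=C/CC[C@@H]1[C@@]2(C)CCC(=O)C(C)(C)[C@H]2CC[C@@]1(C)O)CC/C=C(\C)C(=O)OCc1cn(-c2ccc([N+](=O)[O-])cc2)nn1` carries a 4-nitrophenyl group, and in this assay compound 2 gives > 150000 nM, again a limit. Compound 3 `C/C(=C\CC/C(C)=C/CC[C@@H]1[C@@]2(C)CCC(=O)C(C)(C)[C@H]2CC[C@@]1(C)O)CC/C=C(\C)C(=O)OCc1cn(-c2ccc(F)cc2)nn1` carries a 4-fluorophenyl group, and in this assay compound 3 gives > 150000 nM, once more a limit. Compound 3 thus stands exactly where every measured value stands, as the limit of > 150000 nM in this assay, at which 3 of the 3 values shown sit, records. The steps a step that the two limits leave unreadable from compound 1 to compound 2, a step that the two limits leave unreadable from compound 1 to compound 3 and a step that the two limits leave unreadable from compound 2 to compound 3 cannot be sized for that reason.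

Compound 4 `C/C(=C\CC/C(C)=C/CC[C@@H]1[C@@]2(C)CCC(=O)C(C)(C)[C@H]2CC[C@@]1(C)O)CC/C=C(\C)C(=O)OCc1cn(-c2ccc(C(C)(C)C)cc2)nn1` differs from compound 3 by tert-butyl in place of fluoro on an aromatic carbon. No measured step can be read, so nothing yet gives a basis for expecting a shift in this assay in either direction for compound 4; every ring variation tried so far left the value at the limit. The expected step is a step that the limit leaves unreadable from compound 3 to compound 4, which would again be swallowed by the limit. Compound 4 is therefore estimated at 200000 nM, with a range from 80000 nM to 600000 nM.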

Compound 4, half-maximal inhibitory concentration: 65800 nM
Compound 4: middle estimate off by 3.0-fold (0.48 log units), on the high side; the whole stated range lies above it.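

In this assay, compound 4 is the only compound shown whose value is a number rather than a limit, so a change at this place on the phenyl ring can register in the read-out: the limit of > 150000 nM in this assay, at which 3 of the 4 values shown sit. Tert-butyl in place of fluoro gives an at least 2.2-fold lower number from compound 3 to compound 4 (0.35 log units; beyond the scatter), tert-butyl in place of nitro gives an at least 2.2-fold lower number from compound 2 to compound 4 (0.35 log units; beyond the scatter), and 4-(tert-butyl)phenyl in place of 2-(trifluoromethyl)phenyl gives an at least 2.2-fold lower number from compound 1 to compound 4 (0.35 log units; beyond the scatter). The partner in each pair sits at a limit, so each of these steps gives only a minimum size, while the steps among compound 1, compound 2 and compound 3 still cannot be read.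

With one tert-butyl compound as the only reading below the limit, the compounds shown cannot tell whether the lower number is particular to tert-butyl or would also appear with other groups in the same place. An amine, a carboxylic acid or a longer carbon chain on the phenyl ring would help to show whether the value follows a trend or whether compound 4 stands alone.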